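Cytotoxicity notes: swapping the dimethylphenyl substitution pattern

The source may hold more compounds than are shown below. What is called first, only, known or untested is meant among the compounds shown, and "the series" means these compounds.

Measured so far:
compound 1 `Cc1cc(-c2ccc(C#N)cc2)cc(C)c1Nc1ccnc(Nc2ccc(C#N)cc2)n1` gives 2080 nM in an ADME assay on MT4 cells (Homo sapiens) for cytotoxicity, read by MTT assay, with a stated time of 4 days; a lower number here means that less compound is tolerated, a higher number that more compound is tolerated.
compound 2 `Cc1cc(C)cc(-c2cc(C)c(Nc3ccnc(Nc4ccc(C#N)cc4)n3)c(C)c2)c1` gives 4140 nM in this assay.

Compound 2 holds the highest of the two numbers in this assay; its nearest neighbour is compound 1, and the gap between the two is within the scatter. For the measured compounds named here, the only measured step, a 2.0-fold higher number from compound 1 to compound 2 (0.30 log units; within the scatter), is therefore a change of the distal aryl group that left the read-out essentially where it was.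

Compound 3 `Cc1cc(-c2c(C)cccc2C)cc(C)c1Nc1ccnc(Nc2ccc(C#N)cc2)n1` is the next candidate. It differs from compound 2 in one place: 2,6-dimethylphenyl in place of 3,5-dimethylphenyl on an aromatic carbon. Going by the values given here, no measured step covers this exact rearrangement, so the expectation leans on the one step that does exist, a 2.0-fold higher number from compound 1 to compound 2 (0.30 log units; within the scatter), which shows the distal aryl tolerating a change without moving the read-out beyond the scatter. For compound 3 the expected step is a 1.2-fold lower number from compound 2 to compound 3 (0.07 log units; within the scatter), that is, no change beyond the scatter. The estimate for compound 3 in this assay is 3500 nM, with a range from 1500 nM to 8000 nM.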

Compound 3, half-maximal cytotoxic concentration: 2590 nM
The estimate for compound 3 lay 1.4-fold (0.13 log units) above the measured number; low and high end bracket the measured number.
By their numbers in this assay, from the lowest: compounds 1, 3 and 2 (each within the scatter of the next).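

Rearranging the same carbon atoms from 3,5-dimethylphenyl to 2,6-dimethylphenyl, on an aromatic carbon para to a large group, gives a 1.6-fold lower number from compound 2 to compound 3 (0.20 log units; within the scatter) in this assay, so the placement of the two methyl groups on this ring shows no effect on the read-out beyond the scatter. Replacing 4-cyanophenyl with 2,6-dimethylphenyl gives a 1.2-fold higher number from compound 1 to compound 3 (0.10 log units; within the scatter), which places all three aryl groups at this position within the scatter of one another, with or without a nitrile on the ring. Nothing available here accounts for this flat read-out.

The compounds shown carry only methyl or nitrile on this aryl ring, so it remains open whether an amine or a carboxylic acid there would take the read-out beyond the scatter. On these data alone, a saturated ring in place of the aryl group also remains open, as does whether any of these three groups behaves the same way on a different core.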